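A few compounds are considered here, and "the series" means these few. Any claim that something is new, unique, unknown or untested is made for them only; others in the source may bear on it.

Of the compounds shown here, three built on one shared core have been tested in a functional assay on NCI-H460 cells (Homo sapiens) for antiproliferative activity (a higher number here means a weaker inhibitor, a lower number a stronger inhibitor), and they differ only in the group on the carbonyl carbon. Compound 1 `COc1ccc(S(=O)(=O)Oc2ccccc2NC(=O)c2ccc(F)cc2)cc1`, which carries 4-fluorophenyl there, gives 550 nM. Compound 2 `COc1ccc(S(=O)(=O)Oc2ccccc2NC(=O)c2ccc3ncccc3c2)cc1`, carrying quinolin-6-yl, reaches only a limit of the assay, > 10000 nM. Compound 3 `COc1ccc(S(=O)(=O)Oc2ccccc2NC(=O)c2cccnc2)cc1`, carrying pyridin-3-yl, likewise reaches only a limit, > 6000 nM. Compound 3 therefore stands at the unresolved end of the measured range, with no exact number attached to it. Both readable steps start from compound 1: an at least 18-fold higher number from compound 1 to compound 2 (1.25 log units; beyond the scatter) and an at least 10-fold higher number from compound 1 to compound 3 (1.03 log units; beyond the scatter). The remaining step, a step that the two limits leave unreadable from compound 2 to compound 3, cannot be sized.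

Compound 4 `COc1ccc(S(=O)(=O)Oc2ccccc2NC(=O)Oc2ccccc2)cc1` differs from compound 3 by phenoxy in place of pyridin-3-yl on a carbonyl carbon. Among the compounds with values here, this brings back a ring of carbon only, as in compound 1, but joins it through an oxygen, an arrangement no measured compound shows. Because compound 1 sits well inside the measurable range and the loss in an at least 10-fold higher number from compound 1 to compound 3 (1.03 log units; beyond the scatter) was large, some recovery toward compound 1 is plausible for compound 4, yet the start in compound 3 is only a limit, so the expected step of an at least 2.0-fold lower number from compound 3 to compound 4 (0.30 log units; that floor lies within the scatter) rests on loose ground. Compound 4 is expected to give 3000 nM, within 600 nM to 12000 nM.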

Compound 4, half-maximal inhibitory concentration: > 10000 nM
Compound 4: no number, only a limit (the forecaster's own chance of this, stated with the estimate: 35%); at least 3.3-fold (0.52 log units) between middle value and limit.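

Compound 4 also stops at a limit in this assay, not at a number: the limit of > 10000 nM in this assay, at which 2 of the 4 values shown sit. Putting phenoxy on the carbonyl carbon in place of 4-fluorophenyl gives an at least 18-fold higher number from compound 1 to compound 4 (1.25 log units; beyond the scatter), so a ring of carbon only at this place does not by itself keep the activity of compound 1. The steps from compound 2 and from compound 3 to compound 4 cannot be read, and no order can be given among these three compounds.

Phenoxy differs from 4-fluorophenyl in two ways, the oxygen link and the missing fluorine, and the compounds shown cannot tell which of the two matters; a plain phenyl or a 4-fluorophenoxy group on the same carbonyl carbon would separate them. From the compounds shown here alone, compound 1 is also the only one of the four with an exact value, so it stays open whether other groups at this place, such as a 4-chlorophenyl ring or a short alkyl chain, would give a measurable value.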